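A few compounds are considered here, and "the series" means these few. Any claim that something is new, unique, unknown or untested is made for them only; others in the source may bear on it.

For the measured compounds named here, compound 2, with the structure `CCCOc1cccc(-c2[nH]c3cc(OC)ccc3c(=O)c2C(=O)OCC)c1`, stands highest of the two numbers so far in an in vitro ADME assay on microsomes from liver (Homo sapiens) for metabolic stability, read by HPLC, with a stated time of 4 h (on this read-out lower numbers stand for slow clearance and higher numbers for fast clearance), where compound 2 gives 12 mL.min-1.g-1. Going by the values given here, its nearest neighbour is compound 1, `CCOC(=O)c1c(-c2cccc(-c3ccccc3)c2)[nH]c2cc(OC)ccc2c1=O`, which in this assay gives 5 mL.min-1.g-1; the one step between them, a 2.4-fold higher number from compound 1 to compound 2 (0.38 log units; beyond the scatter), came from putting propoxy in place of phenyl on an aromatic carbon. Compound 3, `CCOC(=O)c1c(-c2cccc(Cl)c2)[nH]c2cc(OC)ccc2c1=O`, is the next member, and it differs from compound 2 by chloro in place of propoxy on an aromatic carbon. Among the compounds with values here, the only measured step that bears on this change is the one from compound 1 to compound 2, in which introducing the propoxy raised the number by a modest amount. Taking the propoxy away again for chloro is therefore expected to move this assay back down by a comparable, modest amount rather than leave it unchanged. On that basis compound 3 is estimated at 6 mL.min-1.g-1, within a range of 3 mL.min-1.g-1 to 13 mL.min-1.g-1, a step of a 2.0-fold lower number from compound 2 to compound 3 (0.30 log units; within the scatter) that is expected rather than established.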

Compound 3, intrinsic clearance in microsomes: 3.4 mL.min-1.g-1
Compound 3: middle estimate off by 1.8-fold (0.25 log units), on the high side; measured number inside the range.
By their numbers in this assay, from the lowest: compounds 3 and 1 (each within the scatter of the next); then compound 2.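

In this assay, the change from propoxy to chloro at this place on the aromatic ring gives a 3.5-fold lower number from compound 2 to compound 3 (0.55 log units; beyond the scatter), so the step seen earlier with propoxy also appears against a second group. Chloro and phenyl, by contrast, read alike here, with a 1.5-fold lower number from compound 1 to compound 3 (0.17 log units; within the scatter), so among these three groups only propoxy stands apart, and a lone chlorine atom and a whole ring give the same picture. Nothing available here accounts for why propoxy stands apart.

Going by these compounds, it remains open whether methoxy or a longer chain such as butoxy would read with propoxy or with chloro and phenyl, and where an amine at this place would fall. On these data alone, the three compounds also vary only at this one place, so whether the same picture holds with another group in place of the ethyl ester is unknown.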